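This account rests on a few compounds, and the source may have more. Where it says the series, first, only, none or still open, it means among the compounds named here.

The three measured compounds fall into two clear groups in a functional assay on HCT-116 cells (Homo sapiens) for inhibition, read by CCK-8 assay, with a stated time of 72 h, tested at 8 uM; a lower number here means less inhibition of growth, a higher number more inhibition of growth at the concentration tested. Compound 1, `Cc1ccc(SCc2ccc(/C=C/C(=O)Nc3ccccc3N)cc2)cc1`, gives 4.93%, the lowest of the three numbers. Compound 2, `Nc1ccccc1NC(=O)c1ccc(CSc2ccc(F)cc2)cc1`, gives 90.6% in this assay, a number that stands beyond the usual scatter above the value of compound 1. Compound 3, `COC(=O)c1ccccc1SCc1ccc(C(=O)Nc2ccccc2N)cc1`, gives 92% in this assay and lies furthest from compound 1, again beyond the scatter. No pair among these three differs in only one place, so nothing here shows how a single change moves the number.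

Compound 4, `CCc1ccc(SCc2ccc(/C=C/C(=O)Nc3ccccc3N)cc2)cc1`, is the unmeasured partner of compound 1. The difference between them is counted as methyl in place of hydrogen on a saturated chain carbon bound to an aromatic carbon, which one bond further out reads as methyl to ethyl on the (4-methylphenyl)sulfanyl group becoming (4-ethylphenyl)sulfanyl. Since compound 1 sits at 4.93% and the change adds only one carbon with no donor or acceptor, no step beyond the scatter is expected in this assay; the expected step is a number 3.1 percentage points higher from compound 1 to compound 4 (within the scatter), essentially flat. Compound 4 is therefore estimated at 8% in this assay, with a range from 0% to 25%.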

Compound 4, percent growth inhibition at one concentration: 2.68%
The estimate for compound 4 lay 5.3 percentage points above the measured number, and the stated range covers the measured number.
By their numbers in this assay, from the lowest: compounds 4 and 1 (each within the scatter of the next); then compounds 2 and 3 (each within the scatter of the next).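

Extending the (4-methylphenyl)sulfanyl group to (4-ethylphenyl)sulfanyl gives the first single-change comparison in this set: in this assay, the step is a number 2.3 percentage points lower from compound 1 to compound 4 (within the scatter). This shows that methyl in place of hydrogen on a saturated chain carbon bound to an aromatic carbon does not measurably alter the reading of this pair, with compound 1 at 4.93% and compound 4 at 2.68%, so the low number of compound 1 is not specific to its methyl group. No measured information is available to explain this flat step.

The compounds shown leave open whether a longer chain such as propyl, or a different group such as an amine or a carboxylic acid, at this place would move the number in this assay beyond the scatter. From the compounds shown here alone, both members of this pair also sit low on the scale, which leaves little room for a further fall, so it remains open whether the same added methyl would stay as flat on a compound that starts from a high number.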